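Swapping an amide for a urea on a shared core

A few compounds are considered here, and "the series" means these few. Any claim that something is new, unique, unknown or untested is made for them only; others in the source may bear on it.

Compound 1 `O=C(Nc1ccc(-n2ccc3c(NC(=O)c4ccccc4)ncnc32)cc1)c1ccc(Cl)c(Cl)c1` is the starting point. In a functional assay on A375P cells (Homo sapiens) for antiproliferative activity, read by MTT assay, with a stated time of 24 h (a higher number here means a weaker inhibitor, a lower number a stronger inhibitor), compound 1 gives 2000 nM. Compound 3 `O=C(Nc1ccc(-n2ccc3c(NC(=O)c4ccccc4)ncnc32)cc1)c1cc(C(F)(F)F)cc(C(F)(F)F)c1` carries a bis(trifluoromethyl)phenyl group in place of the dichlorophenyl of compound 1. In this assay compound 3 gives 2000 nM, level with compound 1 at the digits shown and within the usual scatter of repeated measurements. Compound 2 `CC(=O)Nc1ncnc2c1ccn2-c1ccc(NC(=O)Nc2ccc(Cl)c(C(F)(F)F)c2)cc1` is different: in this assay compound 2 reaches only a limit, > 10000 nM, which means the assay reports no number for it. This is the sense of the limit of > 10000 nM in this assay, at which 1 of the 3 values shown sits.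

The unmeasured compound is compound 4 `O=C(Nc1ccc(-n2ccc3c(NC(=O)c4ccccc4)ncnc32)cc1)Nc1cccc(Cl)c1Cl`. Compared with compound 1, its structure changes in one place: (2,3-dichlorophenyl)amino in place of 3,4-dichlorophenyl on a carbonyl carbon. Among the measured compounds shown here, no pair of measured compounds here is separated by just such a change, so the size of this step is not known from the data. Compound 2 also carries a carbamoyl link, but compound 2 differs from compound 1 in a second place as well, so its limit cannot be tied to that link alone.

The step from compound 1 to compound 4 is expected to be modest, leaning toward weaker, as a 1.5-fold higher number from compound 1 to compound 4 (0.18 log units; within the scatter). Compound 4 is estimated at 3000 nM in this assay, with a likely range from 1000 nM to 10000 nM.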

Compound 4, half-maximal inhibitory concentration: 4100 nM
The estimate for compound 4 lay 1.4-fold (0.14 log units) below the measured number; the range from low to high includes it.
By their numbers in this assay, from the lowest: compounds 1 and 3 (each within the scatter of the next); then compound 4. At a limit, above all of these: compound 2.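

In this assay, among the compounds shown here, this is the first measured step at this position that places a nitrogen on the carbonyl carbon, turning the amide link of compound 1 into the urea link of compound 4, and it is a modest loss (a 2.1-fold higher number from compound 1 to compound 4 (0.31 log units; beyond the scatter)). Until now this position had shown only two aryl groups joined directly to the carbonyl carbon, and compound 1 and compound 3 stood level; the urea link now shows a number that moves, yet compound 4 still gives a measured value of 4100 nM and not a limit. The change alters the link and the placing of the two chlorines together, and nothing measured here explains the step.

From the compounds shown here alone, it remains open whether the step comes from the added amino nitrogen or from the move to the 2,3-dichlorophenyl pattern, a question that a (3,4-dichlorophenyl)amino group on the same carbonyl carbon could settle. Also open, going by these compounds, is how this position responds to a group of a different kind, such as a morpholine or a carboxylic acid on the phenyl ring.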